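From furan to thiazole: an expected cytotoxicity step

The source may hold more compounds than are shown below. What is called first, only, known or untested is meant among the compounds shown, and "the series" means these compounds.

Compound 2 `O=c1[nH]c(=O)n(C2C=CC(O)C2)cc1-c1ccco1` and compound 1 `O=c1[nH]c(=O)n(C2C=CC(O)C2)cc1-c1cccs1` differ only in the five-membered ring attached to the shared core. In an ADME assay on Vero cells (Chlorocebus sabaeus) for cytotoxicity, read by microscopy (on this read-out lower numbers stand for higher toxicity in this test and higher numbers for lower toxicity in this test), compound 1 gives 20000 nM. Compound 2 gives > 100000 nM, which is a limit of the assay and not a number, so for compound 2 all that is known is the limit of > 100000 nM in this assay, at which 1 of the 2 values shown sits. Within the data shown here, the one measured step, an at least 5.0-fold higher number from compound 1 to compound 2 (0.69 log units; beyond the scatter), places the furan compound on the less toxic side. Compound 3 `O=c1[nH]c(=O)n(C2C=CC(O)C2)cc1-c1cncs1` carries the change (1,3-thiazol-5-yl in place of furan-2-yl on an aromatic carbon). Among the measured compounds shown here, no measured step covers a thiazole, so the one step bears only indirectly: a ring sulfur, which compound 1 also carries, comes back, while furan-2-yl leaves. Compound 3 is therefore expected to sit in this assay at or somewhat below the limit, estimated at 80000 nM within 25000 nM to 150000 nM, an expected step of an at least 1.2-fold lower number from compound 2 to compound 3 (0.09 log units; that floor lies within the scatter).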

Compound 3, minimum cytotoxic concentration: > 100000 nM
Compound 3: a limit, no number (the forecaster's own chance of this, stated with the estimate: 45%); middle value at least 1.2-fold (0.09 log units) from the limit.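

With 1,3-thiazol-5-yl on this aromatic carbon, this assay shows an at least 5.0-fold higher number from compound 1 to compound 3 (0.69 log units; beyond the scatter), so a ring sulfur alone does not bring back the lower number seen with thiophen-2-yl. Of the three rings shown, thiophen-2-yl is now the only one that gives a readable number, while furan-2-yl and 1,3-thiazol-5-yl both end at a limit of the assay. The step from compound 2 to compound 3 cannot be read, because both compounds rest on the same limit: the limit of > 100000 nM in this assay, at which 2 of the 3 values shown sit.

On these data alone, how far compound 2 and compound 3 actually differ therefore stays open. Also open, as far as these compounds go, is whether a different group on this aromatic carbon, such as an amine or a carboxylic acid, would give a number within the range of this assay.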